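Swapping the ester-like group on a furan-bearing core

The source may report more compounds than this note shows. Statements on the series, on what has been measured and on what is new or still open speak of the compounds shown alone.

Compound 1 `CCCC(=O)C1=C(C)NC(=O)NC1c1ccco1` gives 1%.
Compound 2 `CC1=C(C(=O)NC(C)C)C(c2ccco2)NC(=O)N1` gives 3%.
Compound 3 `CC1=C(C(=O)SC(C)C)C(c2ccco2)NC(=O)N1` gives 5%.

These were measured in an assay on membranes from CHO cells for displacement of a labelled ligand from adenosine receptor A1 (Homo sapiens), read by scintillation counting, with a stated time of 60 min, tested at 1 uM; on this read-out higher numbers stand for more inhibition at the one concentration tested (going by the name of the read-out) and lower numbers for less inhibition. Compound 3 carries the highest of the three numbers, yet the gaps separating it from the others, a number 2 percentage points higher from compound 2 to compound 3 (within the scatter) and a number 4 percentage points higher from compound 1 to compound 3 (within the scatter), are both within the scatter, so the three compounds cannot be told apart. Compound 4 `CCC(CC)OC(=O)C1=C(C)NC(=O)NC1c1ccco1` differs from compound 3 by (pentan-3-yl)oxy in place of isopropylsulfanyl on a carbonyl carbon. The two steps that also change the group on that carbonyl carbon, a number 4 percentage points higher from compound 1 to compound 3 (within the scatter) and a number 2 percentage points higher from compound 2 to compound 3 (within the scatter), were both within the scatter, and a number 2 percentage points higher from compound 1 to compound 2 (within the scatter) likewise. The expected step to compound 4 is therefore no change at the digits printed from compound 3 to compound 4 (within the scatter), nothing beyond the scatter. Compound 4 is estimated at 5%, with a range from 0% to 15%.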

Compound 4, a percentage reported as inhibition, at one concentration (the size of the read-out at that concentration, not a potency): 2%
Beside the measured number, compound 4's estimate is 3 percentage points above it; measured number inside the range.
By their numbers in this assay, from the lowest: compounds 1, 4, 2 and 3 (each within the scatter of the next).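

In this assay, placing (pentan-3-yl)oxy on the carbonyl carbon gives a number 3 percentage points lower from compound 3 to compound 4 (within the scatter), a number 1 percentage points lower from compound 2 to compound 4 (within the scatter) and a number 1 percentage points higher from compound 1 to compound 4 (within the scatter). All four groups tried at this position, with a carbon, nitrogen, sulfur or oxygen attached to the carbonyl carbon, therefore remain indistinguishable, and this now includes the branched oxygen-linked group. Nothing available explains this result. Going by these compounds, whether any group here can raise the number beyond the scatter stays open, for example a carboxylic acid or a benzyloxy group.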